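Extending the basic side chain of a urea hydrazone

The compounds below may be only part of what the source reports. "The series", "measured", "known", "first", "only" and "open" are said of these compounds alone.

The study concerns three ureas sharing one core. Compound 1 `O=C(N/N=C/c1ccc(Br)cc1)Nc1ccc(Oc2ccnc3[nH]ccc23)cc1` was recorded as "not active" (no number reported) in a functional assay on PC-3 cells (Homo sapiens) for antiproliferative activity, read by MTT assay, with a stated time of 72 h; a higher number here means a weaker inhibitor, a lower number a stronger inhibitor. Going by the values given here, compound 2 `CN(C)CCn1cccc1/C=N/NC(=O)Nc1ccc(Oc2ccnc3[nH]ccc23)cc1` is the only member with a numerical result: in this assay compound 2 gives 3930 nM, so it stands alone as the sole measured point, and with compound 1 giving no number there is no comparison to draw. Compound 3 `O=C(N/N=C/c1cccn1CCCN1CCCC1)Nc1ccc(Oc2ccnc3[nH]ccc23)cc1` has not yet been tested in this assay. It differs from compound 2 in one place: (pyrrolidin-1-yl)methyl in place of dimethylamino on a saturated chain carbon, two bonds along the chain from an aromatic nitrogen. Among the compounds with values here, no step between measured compounds exists to set the scale of such a change, so the expectation rests on compound 2 alone. Compound 3 is expected to give a result close to that of compound 2, with a shift from compound 2 to compound 3 of a 1.3-fold lower number from compound 2 to compound 3 (0.12 log units; within the scatter), not clearly beyond the scatter. The estimate for compound 3 in this assay is 3000 nM, within 1200 nM to 8000 nM.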

Compound 3, half-maximal inhibitory concentration: 4290 nM
The estimate for compound 3 lay 1.4-fold (0.16 log units) below the measured number; low and high end bracket the measured number.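

The step gives this position its first scale in this assay: (pyrrolidin-1-yl)methyl in place of dimethylamino, on a saturated chain carbon two bonds along the chain from an aromatic nitrogen, gives a 1.1-fold higher number from compound 2 to compound 3 (0.04 log units; within the scatter) in this pair. Read one bond further out, 2-(dimethylamino)ethyl and 3-(pyrrolidin-1-yl)propyl, the latter with its five-membered non-aromatic ring, are not told apart in this assay, so this position accepts the larger group with no change beyond the scatter. Nothing at hand accounts for this result.

As far as these compounds go, whether a morpholine ring, a piperidine ring or a carboxylic acid at the end of the chain would leave the number equally undisturbed remains open. Compound 1 gives no number, so it sets no scale for this or any other change.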